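A few compounds are considered here, and "the series" means these few. Any claim that something is new, unique, unknown or untested is made for them only; others in the source may bear on it.

In this study the measurement of interest is an ADME assay on liver for metabolic stability, with Liver microsome (Homo sapiens) as the target, read by LC-MS, using microsomes; a higher number here means faster removal of the compound, a lower number slower removal. Three compounds already carry a reading. Compound 1 `COC(C)(C)[C@@H](O)C(=O)N1[C@H](C(=O)NCc2cc(Cl)ccc2-n2cnnn2)C[C@@H]2C[C@@H]21` gives 40 mL.min-1.g-1 in this assay. Compound 3 `O=C([C@H](O)c1ccccc1)N1CC[C@@H]2C[C@@]21C(=O)NCc1cc(Cl)ccc1-n1cnnn1` keeps much of the core of compound 1 but carries a different side group. In this assay compound 3 gives 43 mL.min-1.g-1. That number is so close to the reading of compound 1 that the two lie within the usual scatter of each other and neither can be said to be cleared faster or slower. Compound 2 `CC1(C[C@@H](O)C(=O)N2N=CC[C@H]2C(=O)NCc2cc(Cl)ccc2-n2cnnn2)CC1` gives no number at all in this assay, only a limit, < 12 mL.min-1.g-1, which is the limit of < 12 mL.min-1.g-1 in this assay, at which 1 of the 3 values shown sits.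

Compound 4 `CC(C)(C)C[C@@H](O)C(=O)N1[C@H](C(=O)NCc2cc(Cl)ccc2-n2cnnn2)C[C@@H]2C[C@@H]21` has not yet been measured. It differs from compound 1 in a single place: neopentyl in place of 1-methoxy-1-methylethyl on a saturated chain carbon bound to a carbonyl carbon and an oxygen on a saturated carbon. Within the data shown here, no measured pair in this set shows the same change, so the expectation can rest only on the reading of compound 1 and on the change itself. The step from compound 1 to compound 4 in this assay is expected to be modest, likely upward but within or near the scatter, at a 1.4-fold higher number from compound 1 to compound 4 (0.14 log units; within the scatter). Compound 4 is therefore estimated at 55 mL.min-1.g-1 in this assay, with a range from 22 mL.min-1.g-1 to 130 mL.min-1.g-1.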

Compound 4, intrinsic clearance in microsomes: 40 mL.min-1.g-1
For compound 4 the middle estimate is 1.4-fold (0.14 log units) above the measured one; the range from low to high includes it.
By their numbers in this assay, from the lowest: compounds 1, 4 and 3 (each within the scatter of the next). At a limit, below all of these: compound 2.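

In this assay, among these compounds, the only single-place step in this set, neopentyl in place of 1-methoxy-1-methylethyl, shows no change at the digits printed from compound 1 to compound 4 (within the scatter) on a saturated chain carbon bound to a carbonyl carbon and an oxygen on a saturated carbon. Among the compounds shown here, this is the first direct look at this position: the two groups have the same heavy-atom count, but the oxygen and the hydrogen-bond acceptor of 1-methoxy-1-methylethyl are absent from neopentyl, and the reading on the core of compound 1 does not separate the two. Nothing measured here bears on why these two groups read alike.

Going by these compounds, one step at one position speaks only for this pair, so it remains open whether a different kind of group here, such as an amine, a carboxylic acid or a longer chain, would shift the reading in either direction. Compound 2 and compound 3 differ from compound 1 in more than one place, so the steps to them cannot be read, and they add nothing about this position.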